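Iodo in place of methoxy on the aryl urea

The compounds below may be only part of what the source reports. "The series", "measured", "known", "first", "only" and "open" are said of these compounds alone.

Measured so far:
compound 1 `O=C(Nc1cccc(C(=O)O)c1)N[C@H]1CC[C@H](Oc2ccc(F)cc2)CC1`: > 20000 nM
compound 2 `O=C(Nc1cccc(Br)c1)N[C@H]1CC[C@H](Oc2ccc(F)cc2)CC1`: 6200 nM
compound 3 `COc1cccc(NC(=O)N[C@H]2CC[C@H](Oc3ccc(F)cc3)CC2)c1`: 14000 nM

In a functional assay on CRL2813 cells (Homo sapiens) for cytotoxicity, read by sulforhodamine B assay, with a stated time of 5 days (on this read-out lower numbers stand for stronger inhibition and higher numbers for weaker inhibition), compound 1 reports only a limit, > 20000 nM; that is the limit of > 20000 nM in this assay, at which 1 of the 3 values shown sits. Of the two actual numbers, compound 3 sits highest with 14000 nM, its nearest neighbour being compound 2 at 6200 nM. The measured steps are an at least 3.2-fold lower number from compound 1 to compound 2 (0.50 log units; beyond the scatter), an at least 1.4-fold lower number from compound 1 to compound 3 (0.15 log units; that floor lies within the scatter) and a 2.3-fold higher number from compound 2 to compound 3 (0.35 log units; beyond the scatter).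

The next compound is compound 4 `O=C(Nc1cccc(I)c1)N[C@H]1CC[C@H](Oc2ccc(F)cc2)CC1`. It differs from compound 3 as follows: iodo in place of methoxy on an aromatic carbon. Among the compounds with values here, the step that bears on it is the one between compound 2 and compound 3, a 2.3-fold higher number from compound 2 to compound 3 (0.35 log units; beyond the scatter), which runs in the opposite direction for a halogen replaced by methoxy. Going from methoxy back to a halogen is therefore expected to give a lower number, of roughly that size: the estimated step is a 2.3-fold lower number from compound 3 to compound 4 (0.37 log units; beyond the scatter). Compound 4 is accordingly expected to give about 6000 nM in this assay, within a range of 2500 nM to 15000 nM.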

Compound 4, half-maximal inhibitory concentration: 5200 nM
Compound 4: the middle estimate sits 1.2-fold (0.06 log units) above what was measured; the measured number falls inside the stated range.
By their numbers in this assay, from the lowest: compounds 4 and 2 (each within the scatter of the next); then compound 3. At a limit, above all of these: compound 1.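

In this assay, a 1.2-fold lower number from compound 2 to compound 4 (0.08 log units; within the scatter), so iodo and bromo at this position cannot be told apart, and the second halogen gives the same picture as the first. Against methoxy, iodo gives a 2.7-fold lower number from compound 3 to compound 4 (0.43 log units; beyond the scatter), so the gap seen with bromo now holds for two halogens, with neither compound 2 nor compound 4 going against it. Against the carboxy compound the step is only a floor, an at least 3.8-fold lower number from compound 1 to compound 4 (0.58 log units; beyond the scatter), and compound 1 reports a limit rather than a number: the limit of > 20000 nM in this assay, at which 1 of the 4 values shown sits.

From the compounds shown here alone, whether chloro, fluoro or an amine at this place would stay with compound 2 and compound 4 or fall nearer compound 3 remains open. Also open, going by these compounds, is whether iodo would give a similar number elsewhere on the ring, since all the groups shown sit meta to a large group.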